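A few compounds are considered here, and "the series" means these few. Any claim that something is new, unique, unknown or untested is made for them only; others in the source may bear on it.

Measured compounds:
- compound 1, `Nc1cc(N)c2nc(-c3ccccc3)c(Oc3ccc(Cl)c(Cl)c3)nc2c1`: 47900 nM
- compound 2, `COc1cc(CNc2nc3cc(N)cc(N)c3nc2-c2ccccc2)cc(OC)c1OC`: 15500 nM

Of the compounds shown here, two sharing the same core have been tested in a functional assay on UACC-62 cells (Homo sapiens) for inhibition, read by sulforhodamine B assay, with a stated time of 48 h; a higher number here means a weaker inhibitor of growth, a lower number a stronger inhibitor of growth. In this assay compound 1 gives 47900 nM, the higher of the two numbers, so it is the weaker growth inhibitor of the pair. Compound 2 gives 15500 nM, a lower number, and the gap between compound 1 and compound 2 is larger than the usual scatter of repeated measurements. Going by the values given here, compound 2 differs from compound 1 in more than one place, so no single structural step between them is described here; their two values are simply what is known.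

The piece now turns to compound 3, `Nc1cc(N)c2nc(-c3ccccc3)c(Sc3ccc(F)cc3)nc2c1`, which has not yet been measured in this assay. It is made from compound 1 by one change: (4-fluorophenyl)sulfanyl in place of 3,4-dichlorophenoxy on an aromatic carbon. Among the compounds with values here, no measured pair in this set shows the effect of such a change, so no size or direction for the step can be read from existing numbers. Compound 3 is therefore expected to land close to compound 1, with a step of a 1.2-fold lower number from compound 1 to compound 3 (0.08 log units; within the scatter) treated as no more than the scatter would allow. The estimate for compound 3 in this assay is 40000 nM, with a range from 10000 nM to 150000 nM.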

Compound 3, concentration for total growth inhibition: 31600 nM
Compound 3: middle estimate off by 1.3-fold (0.10 log units), on the high side; measured number inside the range.
By their numbers in this assay, from the lowest: compound 2; then compounds 3 and 1 (each within the scatter of the next).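

Going by these compounds alone, this is the first reading of what a replacement does at this aromatic carbon, the one next to the ring nitrogen and ortho to the phenyl group. In this assay putting (4-fluorophenyl)sulfanyl in place of 3,4-dichlorophenoxy gives a 1.5-fold lower number from compound 1 to compound 3 (0.18 log units; within the scatter) and so leaves compound 1 and compound 3 not separable in this read-out, even though the atom linking the ring to the core and the halogens on that ring are both different. Nothing available accounts for this outcome, and the data cannot say whether the two differences have little effect or offset each other.

This single step covers the linking atom and the halogens together, so a fluorophenoxy group or a dichlorophenylsulfanyl group would be needed to read each difference alone. It also leaves open whether a group of another kind on this carbon, such as a carboxylic acid, a morpholine amine or a longer alkyl chain, would give a number that stands clear of the scatter from compound 1.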